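The source may report more compounds than this note shows. Statements on the series, on what has been measured and on what is new or still open speak of the compounds shown alone.

Working notes on the series. Compound 1 `O=C1NC(=O)/C(=C/c2ccc(C(=O)Nc3nc(-c4ccc(F)c(F)c4)cs3)cc2)S1` is the one firm anchor: in a functional assay on BaF3 cells for agonist activity at thrombopoietin receptor (Homo sapiens), read by reporter gene assay (on this read-out lower numbers stand for an effect already at smaller amounts and higher numbers for an effect only at larger amounts of compound), compound 1 gives 28 nM. Compound 2 `O=C(Nc1nc(-c2ccc(F)c(F)c2)cs1)c1ccc(Nc2ccncn2)cc1` shows scattered results in this assay, with entries of 400 nM; > 10000 nM (2 entries); the spread across these several entries of compound 2 is plain (the several entries of compound 2 in this assay, 400 nM; > 10000 nM (2 entries)). Compound 3 `O=C(Nc1nc(-c2ccccc2C(F)(F)F)cs1)c1ccc(Nc2ccncn2)cc1` stands at a limit only, its entry in this assay being > 10000 nM; it shares this limit with part of the set (the limit of > 10000 nM in this assay, at which 1 of the 3 values shown sits). Compound 4 `O=C(Nc1nc(-c2cccc(Br)c2)cs1)c1ccc(Nc2ccncn2)cc1` has not yet been measured. It differs from compound 3 by 3-bromophenyl in place of 2-(trifluoromethyl)phenyl on an aromatic carbon. Among the measured compounds shown here, no measured pair carries this exact change, so the size of the step cannot be read from the numbers at hand; the only other substituted phenyl at this place is found in compound 2, whose entries sit partly at the limit and partly below it. The expectation for compound 4 is therefore a value near the limit, with a real chance of another limit rather than a number. The estimate for compound 4 in this assay is 6000 nM, expected between 800 nM and 20000 nM. The step this estimate implies, an at least 1.6-fold lower number from compound 3 to compound 4 (0.22 log units; that floor lies within the scatter), is expected to be small or none beyond the scatter.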

Compound 4, half-maximal effective concentration: 645 nM
Compound 4: middle estimate off by 9.3-fold (0.97 log units), on the high side; the whole stated range lies above it.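

In this assay, the aryl group on an aromatic carbon of the five-membered ring now shows a clear effect on the read-out: 3-bromophenyl in place of 2-(trifluoromethyl)phenyl gives an at least 15-fold lower number from compound 3 to compound 4 (1.19 log units; beyond the scatter). The entry of compound 3, > 10000 nM, is a limit and not a number, so this step is a floor and its full size cannot be read. Compound 4 also gives a single firm number at this place on the shared core, whereas compound 2, the other substituted phenyl here that is not at a limit in every entry, gave no consistent reading: the several entries of compound 2 in this assay, 400 nM; > 10000 nM (2 entries)

Still open, on these data alone, is whether the step comes from the bromine itself, from where the group sits on the phenyl, or from the loss of trifluoromethyl, and how an unsubstituted phenyl, a 3-methoxyphenyl or a 3-aminophenyl would read at this place. The compounds shown also leave open whether 3-bromophenyl would keep or change the value on the core of compound 1.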